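Fluoro added to an inactive phenyl compound

The source may report more compounds than this note shows. Statements on the series, on what has been measured and on what is new or still open speak of the compounds shown alone.

Compound 1 `COc1cc(-n2ncnc2-c2ccc(Cl)c(Cl)c2)cc(OC)c1OC` gives > 10000 nM as a limit
Compound 2 `COc1cc(-n2ncnc2-c2ccccc2)cc(OC)c1OC` gives > 10000 nM as a limit

In a functional assay on HeLa cells (Homo sapiens) for antiproliferative activity, read by MTT assay, with a stated time of 72 h (on this read-out lower numbers stand for stronger inhibition and higher numbers for weaker inhibition), compound 2 gives > 10000 nM as a limit, so it has no exact number of its own. Both measured compounds stand at the limit of > 10000 nM in this assay, at which 2 of the 2 values shown sit, and neither has a readable potency.

Compound 3 `COc1cc(-n2ncnc2-c2cccc(F)c2)cc(OC)c1OC` differs from compound 2 by a single change: fluoro in place of hydrogen on an aromatic carbon and in words, fluoro in place of hydrogen on an aromatic carbon. Going by the values given here, only one measured step bears on this, namely a step that the two limits leave unreadable from compound 1 to compound 2 and it swaps 3,4-dichlorophenyl for phenyl. That step offers no size to carry over. Neither of these two compounds gave a value inside the measurable range, however, so the phenyl and the 3,4-dichlorophenyl versions offer no sign of activity to build on. In this assay no step beyond the scatter is therefore expected, and another limit is quite likely.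

Compound 3 is estimated at about 12000 nM with an expected range from 4000 nM to 40000 nM around that figure. The expected change is a step that the limit leaves unreadable from compound 2 to compound 3 as an estimate only.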

Compound 3, half-maximal inhibitory concentration: > 10000 nM
Compound 3 was reported as a limit; the forecaster's own chance of this, stated with the estimate: 80%; the middle value does not contradict the limit.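

Going by these compounds alone, no step between compound 1, compound 2 and compound 3 can be read, because all three stand at the same limit and none has an exact number: the limit of > 10000 nM in this assay, at which 3 of the 3 values shown sit. The compounds shown leave open whether any other group on the shared core would give a value inside the measurable range.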